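Isopropyl on the benzyl arm: compound 4 from compound 1

This account rests on a few compounds, and the source may have more. Where it says the series, first, only, none or still open, it means among the compounds named here.

Three acetylated nucleoside analogues share one core and were examined in a functional assay on NCI-H23 cells (Homo sapiens) for cytotoxicity, read by sulforhodamine B assay, tested at 10 uM; a higher number here means more inhibition at the concentration tested (going by the name of the read-out), a lower number less inhibition. Compound 1 `CC(=O)OC[C@H]1O[C@@H](n2cc(-c3cn(Cc4ccccc4)nn3)c(=O)[nH]c2=O)C[C@@H]1OC(C)=O` gives 98.2%. Compound 2 `CC(=O)OC[C@H]1O[C@@H](n2cc(-c3cc(C)no3)c(=O)[nH]c2=O)C[C@@H]1OC(C)=O` gives 101%, and compound 3 `CCCc1cc(-c2cn([C@H]3C[C@H](OC(C)=O)[C@@H](COC(C)=O)O3)c(=O)[nH]c2=O)on1` gives 96.9%. Compound 1 stands within the usual scatter of both of the other two, so the three numbers cannot be told apart with confidence.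

Compound 4 `CC(=O)OC[C@H]1O[C@@H](n2cc(-c3cn(Cc4ccc(C(C)C)cc4)nn3)c(=O)[nH]c2=O)C[C@@H]1OC(C)=O` has not yet been measured. It differs from compound 1 in one place: isopropyl in place of hydrogen on an aromatic carbon. Within the data shown here, the only measured step that resembles this change, an extension of a small saturated group on a ring substituent, is a number 4.1 percentage points lower from compound 2 to compound 3 (within the scatter), which stayed within the scatter. That single precedent gives no sign that adding carbon at such a position moves the read-out in either direction, and the numbers of the measured compounds already sit high in this assay, leaving little room for a rise.

Compound 4 is therefore expected to show a number 2.2 percentage points lower from compound 1 to compound 4 (within the scatter), a shift not beyond the scatter. The estimated value for compound 4 is 96%, within a range of 86% to 101%.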

Compound 4, a percentage reported as inhibition, at one concentration (the size of the read-out at that concentration, not a potency): 86.7%
For compound 4 the middle estimate is 9.3 percentage points above the measured one; the range from low to high includes it.
By their numbers in this assay, from the lowest: compound 4; then compounds 3, 1 and 2 (each within the scatter of the next).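

In this assay, isopropyl in place of hydrogen on an aromatic carbon of the benzyl arm, para to a large group, gives a number 11.5 percentage points lower from compound 1 to compound 4 (beyond the scatter), so this position responds to added carbon by a modest but real amount. The only earlier step, a number 4.1 percentage points lower from compound 2 to compound 3 (within the scatter), gave no such sign, and it lay on a different ring substituent, so the benzyl arm is the one place among these compounds where a single change takes the read-out beyond the scatter, though compound 4 still gives 86.7% and the finding rests on one example. Nothing measured here bears on why the number falls with this change.

The compounds shown leave open whether a shorter group such as methyl, a longer chain such as butyl, or a different group such as an amine or a carboxylic acid on the same carbon would give a step of similar size. They also leave open whether isopropyl elsewhere on the ring would lower the number at all, and how the change would appear as a potency rather than at one concentration.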